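The source may report more compounds than this note shows. Statements on the series, on what has been measured and on what is new or still open speak of the compounds shown alone.

Measured compounds:
Compound 1 `CCOC(=O)C1=C(S[C@@H]2CN[C@H](C(=O)Nc3cccc(C(=O)OCC)c3)C2)[C@H](C)[C@@H]2[C@@H]([C@@H](C)OC(=O)[C@@H](N)C(C)C)C(=O)N12`: in an ADME assay for metabolic stability, read by LC-MS, with a stated time of 3 h, at pH 6.5, tested at 50 uM (on this read-out higher numbers stand for a more stable compound and lower numbers for a less stable compound), compound 1 reaches the assay limit > 95%, a limit rather than a number.
Compound 2 `CCOC(=O)C1=C(S[C@H]2C[C@@H](C(=O)Nc3cccc(C(=O)OCC)c3)N(C(=O)OCc3oc(=O)oc3C)C2)[C@H](C)[C@@H]2[C@@H]([C@@H](C)O)C(=O)N12`: in this assay compound 2 likewise reaches the limit > 95%.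
Compound 3 `CCOC(=O)C1=C(S[C@@H]2CN[C@H](C(=O)Nc3cccc(C(=O)OCC)c3)C2)[C@H](C)[C@@H]2[C@@H]([C@@H](C)O)C(=O)N12`: in this assay compound 3 also reaches the limit > 95%.

Compound 3 thus stands at the limit, as do the other two measured compounds (the limit of > 95% in this assay, at which 3 of the 3 values shown sit). Compound 4 `CCOC(=O)C1=C(S[C@H]2C[C@@H](C(=O)Nc3cccc(C(=O)OCC)c3)N(Cc3oc(=O)oc3C)C2)[C@H](C)[C@@H]2[C@@H]([C@@H](C)O)C(=O)N12` differs from compound 3 by a group of 8 heavy atoms (5 carbon, 3 oxygen; one five-membered aromatic ring with 2 hetero atoms) in place of a hydrogen atom, on an amine nitrogen in a ring. The measured steps that bear on this change are a step that the two limits leave unreadable from compound 2 to compound 3 and a step that the two limits leave unreadable from compound 1 to compound 3; both are unreadable because the limit of > 95% in this assay, at which 3 of the 3 values shown sit, yields no number on either side. The expected step of a number no higher from compound 3 to compound 4 (the limit leaves the size open) is therefore none beyond the scatter. Compound 4 is expected to give 95%, with a range from 85% to 100%.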

Compound 4, percent of the compound remaining: > 95%
Compound 4 ended at the assay's limit (the forecaster's own chance of this, stated with the estimate: 80%); the middle value sits exactly at the limit.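

No step from compound 2 or compound 3 to compound 4 can be read, because every value is a limit rather than a number: the limit of > 95% in this assay, at which 4 of the 4 values shown sit. The compounds shown leave open how large any of these steps is in this assay.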